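Benzylidene-piperidinone triazoles: fluorine for chlorine on the benzyl

The source may report more compounds than this note shows. Statements on the series, on what has been measured and on what is new or still open speak of the compounds shown alone.

Measured compounds in a functional assay on DU-145 cells (Homo sapiens) for cytotoxicity, read by MTT assay, with a stated time of 24 h; a higher number here means a weaker inhibitor, a lower number a stronger inhibitor:
- compound 1, `COc1ccc(/C=C2\CN(C(=S)SCc3cn(Cc4ccccc4F)nn3)C/C(=C\c3ccc(OC)cc3)C2=O)cc1`, gives 54500 nM
- compound 2, `COc1ccc(/C=C2\CN(C(=S)SCc3cn(Cc4cccc(Cl)c4)nn3)C/C(=C\c3ccc(OC)cc3)C2=O)cc1`, gives only a limit of the assay, > 80000 nM
- compound 3, `Cc1ccc(/C=C2\CN(Cc3cn(Cc4cccc(Cl)c4)nn3)C/C(=C\c3ccc(C)cc3)C2=O)cc1`, gives 33100 nM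

The value of compound 2 is a limit, (the limit of > 80000 nM in this assay, at which 1 of the 3 values shown sits), not a number. Going from compound 2 to compound 1, the change is 2-fluorophenyl in place of 3-chlorophenyl on a saturated chain carbon bound to an aromatic nitrogen, and the step is an at least 1.4-fold lower number from compound 2 to compound 1 (0.16 log units; that floor lies within the scatter). Compound 3 shares the triazole-benzyl part of compound 2, but the difference between the two cores is not broken down here; compound 3 stands with the lowest of the two numbers, and its gap to compound 1 lies within the scatter.

Compound 4, `Cc1ccc(/C=C2\CN(Cc3cn(Cc4ccccc4F)nn3)C/C(=C\c3ccc(C)cc3)C2=O)cc1`, is compound 3 with the same change: 2-fluorophenyl in place of 3-chlorophenyl on a saturated chain carbon bound to an aromatic nitrogen. In this assay the step from compound 3 to compound 4 is expected to be a 1.3-fold lower number from compound 3 to compound 4 (0.12 log units; within the scatter), resting on the earlier step of an at least 1.4-fold lower number from compound 2 to compound 1 (0.16 log units; that floor lies within the scatter), whose floor lies within the scatter. Compound 4 is therefore estimated at 25000 nM, between 10000 nM and 60000 nM.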

Compound 4, half-maximal inhibitory concentration: 9500 nM
The estimate for compound 4 lay 2.6-fold (0.42 log units) above the measured number; the whole stated range lies above it.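

In this assay, 2-fluorobenzyl in place of 3-chlorobenzyl on the core of compound 3 brings a 3.5-fold lower number from compound 3 to compound 4 (0.54 log units; beyond the scatter). This change can be set beside the same change on the core of compound 1, but that comparison does not show whether the size of the step carries from one core to the other: the same change on two cores in this assay, an at least 1.4-fold lower number (0.16 log units; that floor lies within the scatter) from compound 2 to compound 1 and a 3.5-fold lower number (0.54 log units; beyond the scatter) from compound 3 to compound 4; the limit leaves it open whether they differ. The comparison is limited by compound 2, whose value is a limit and not a number: the limit of > 80000 nM in this assay, at which 1 of the 4 values shown sits.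

The change alters both the halogen and its place on the ring, and the compounds shown do not separate the two. As far as these compounds go, what an unsubstituted benzyl group or a longer phenethyl chain would give on either core remains open.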